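Same Aryl Swap, Now on the Methylated Core

This account rests on a few compounds, and the source may have more. Where it says the series, first, only, none or still open, it means among the compounds named here.

Measured so far:
compound 1, `O=C(Nc1ccc(Oc2ccnc3[nH]ccc23)cc1)c1cc2cccnc2n(-c2ccc(Br)cc2F)c1=O` — in a functional assay on HT-29 cells (Homo sapiens) for antiproliferative activity, read by MTT assay, with a stated time of 72 h (a higher number here means a weaker inhibitor, a lower number a stronger inhibitor), compound 1 gives 2360 nM
compound 2, `O=C(Nc1ccc(Oc2ccnc3[nH]ccc23)cc1)c1cc2cccnc2n(-c2ccc(C(F)(F)F)cc2Cl)c1=O` — in this assay compound 2 gives 2160 nM
compound 3, `Cn1ccc2c(Oc3ccc(NC(=O)c4cc5cccnc5n(-c5ccc(Br)cc5F)c4=O)cc3)ccnc21` — in this assay compound 3 gives 2580 nM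

Compound 4, `Cn1ccc2c(Oc3ccc(NC(=O)c4cc5cccnc5n(-c5ccc(C(F)(F)F)cc5Cl)c4=O)cc3)ccnc21`, has not yet been measured in this assay. Two changes connect the measured compounds. The first separates the core of compound 1 from the core of compound 3: methyl in place of hydrogen on an aromatic nitrogen. That change gave a 1.1-fold higher number from compound 1 to compound 3 (0.04 log units; within the scatter), so the two cores cannot be told apart on this evidence. For the measured compounds named here, the second is the one that matters for compound 4. From compound 1 to compound 2 the change is 2-chloro-4-(trifluoromethyl)phenyl in place of 4-bromo-2-fluorophenyl on an aromatic nitrogen, and it gave a 1.1-fold lower number from compound 1 to compound 2 (0.04 log units; within the scatter).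

Compound 4 is compound 3 carrying exactly that change: 2-chloro-4-(trifluoromethyl)phenyl in place of 4-bromo-2-fluorophenyl on an aromatic nitrogen. The surroundings of the place are described in the same words in both cases, so this is the same change made on the methylated core. Going by the values given here, with only one earlier instance to go on, the most reasonable expectation is that it repeats. Compound 4 is therefore expected to differ from compound 3 by about a 1.1-fold lower number from compound 3 to compound 4 (0.03 log units; within the scatter), because the earlier swap gave a 1.1-fold lower number from compound 1 to compound 2 (0.04 log units; within the scatter). For compound 4 the estimated value in this assay is 2400 nM, expected to fall between 1200 nM and 4800 nM.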

Compound 4, half-maximal inhibitory concentration: 6050 nM
Estimate against measurement, compound 4: 2.5-fold (0.40 log units) below; measured number outside the range, above it.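

In this assay, the aryl swap made on the methylated core gave a 2.3-fold higher number from compound 3 to compound 4 (0.37 log units; beyond the scatter), and adding the methyl to the core that carries 2-chloro-4-(trifluoromethyl)phenyl gave a 2.8-fold higher number from compound 2 to compound 4 (0.45 log units; beyond the scatter). Each of these new steps is larger than the scatter, whereas its earlier counterpart is not, but a comparison of two steps carries the scatter of both, so the aryl swap is not shown to behave differently on the two cores, nor is it shown to carry over unchanged: the same change on two cores in this assay, a 1.1-fold lower number (0.04 log units; within the scatter) from compound 1 to compound 2 and a 2.3-fold higher number (0.37 log units; beyond the scatter) from compound 3 to compound 4, 2.6-fold (0.41 log units) apart, within the scatter of two such steps. The methyl change reads the same way, so these four compounds do not establish that the methyl and the aryl group influence each other, and they give no firm ground for expecting either step to repeat exactly on a further core: the same change on two cores in this assay, a 1.1-fold higher number (0.04 log units; within the scatter) from compound 1 to compound 3 and a 2.8-fold higher number (0.45 log units; beyond the scatter) from compound 2 to compound 4, 2.6-fold (0.41 log units) apart, within the scatter of two such steps.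

The compounds shown carry only hydrogen or methyl on that aromatic nitrogen, so it remains open how an ethyl group or a longer chain ending in an amine would fare there. As far as these compounds go, it also remains open whether an aryl group with a methoxy or a nitrile in place of these halogen-bearing substituents would follow compound 3 or compound 4.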